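This account rests on a few compounds, and the source may have more. Where it says the series, first, only, none or still open, it means among the compounds named here.

Of the compounds shown here, three built on one shared core have been measured in an assay on CHO-K1 cells for displacement of a labelled ligand from prostaglandin E2 receptor EP1 subtype (Homo sapiens); a lower number here means a stronger inhibitor, a higher number a weaker inhibitor. Compound 1 `CNC(=O)c1cc(C)n(Cc2cc(Cl)ccc2OCc2ccccc2)n1` gives 100 nM. Compound 2 `CC(=O)Nc1cc(C)n(Cc2cc(Cl)ccc2OCc2ccccc2)n1` gives 316 nM. Compound 3 `Cc1cc(NC(=O)C2CCCC2)nn1Cc1cc(Cl)ccc1OCc1ccccc1` gives 15.9 nM, the lowest of the three numbers: the steps are a 6.3-fold lower number from compound 1 to compound 3 (0.80 log units; beyond the scatter) and a 20-fold lower number from compound 2 to compound 3 (1.30 log units; beyond the scatter), both beyond the usual scatter, so compound 3 is the strongest inhibitor of the three. Compound 4 `Cc1cc(NC(=O)OCC(C)C)nn1Cc1cc(Cl)ccc1OCc1ccccc1` differs from compound 3 in one place: isobutoxy in place of cyclopentyl on a carbonyl carbon. The measured step that bears most on this change is the one altering the same carbonyl carbon, a 20-fold lower number from compound 2 to compound 3 (1.30 log units; beyond the scatter), a large shift from swapping what sits on that carbon. The other two steps, a 3.2-fold higher number from compound 1 to compound 2 (0.50 log units; beyond the scatter) and a 6.3-fold lower number from compound 1 to compound 3 (0.80 log units; beyond the scatter), exchange the whole group attached to the ring and so speak less directly. Among the compounds with values here, no measured pair exchanges cyclopentyl for isobutoxy, so the direction remains open; the entering isobutoxy is as large as the leaving cyclopentyl, and the large gain seen when cyclopentyl replaced methyl is not expected to be undone fully. Compound 4 is therefore expected to give 40 nM, within a range of 12 nM to 130 nM, which corresponds to an expected step of a 2.5-fold higher number from compound 3 to compound 4 (0.40 log units; beyond the scatter).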

Compound 4, half-maximal inhibitory concentration: 25.1 nM
Compound 4: middle estimate off by 1.6-fold (0.20 log units), on the high side, within the range that was stated.
By their numbers in this assay, from the lowest: compounds 3 and 4 (each within the scatter of the next); then compound 1; then compound 2.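

With a 1.6-fold higher number from compound 3 to compound 4 (0.20 log units; within the scatter) as the step, cyclopentyl and isobutoxy on this carbonyl carbon cannot be told apart, which shows that a ring of carbon only is not needed here: an open chain holding an oxygen, with the same 5 heavy atoms, serves as well in this one pair. The large gain over the methyl of compound 2 therefore does not belong to cyclopentyl alone, since a 13-fold lower number from compound 2 to compound 4 (1.10 log units; beyond the scatter) is a step of the same large class as the one cyclopentyl gave. The carbamate-type side chain of compound 4 also stands clear of the methylcarbamoyl of compound 1, with a 4.0-fold lower number from compound 1 to compound 4 (0.60 log units; beyond the scatter) as the step, so both large groups on this carbonyl carbon now beat that arrangement.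

Still open, as far as these compounds go, is how far this tolerance reaches: an isobutyl group would separate the oxygen from the chain, while an ethoxy, a benzyloxy or a cyclohexyl group would test smaller and larger groups on the same carbon. No measurement shown here offers a reason for the match between cyclopentyl and isobutoxy.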